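A few compounds are considered here, and "the series" means these few. Any claim that something is new, unique, unknown or untested is made for them only; others in the source may bear on it.

Of the compounds shown here, two built on the shared core have been measured in a functional assay on MCF7 cells (Homo sapiens) for antiproliferative activity, read by CellTiter-Glo, with a stated time of 5 days; a higher number here means a weaker inhibitor, a lower number a stronger inhibitor. In this assay, compound 1 `CC1=C(c2cccc(O)c2)[C@@H](c2ccc(OC[C@H](C)N3CC[C@@H](C)C3)cc2)Oc2ccc(O)cc21` gives 59 nM, while compound 2 `CC1=C(c2ccc(F)cc2)C(c2ccc(OC[C@H](C)N3CC[C@@H](C)C3)cc2)Oc2ccc(O)cc21` gives 0.4 nM. Compound 2 holds the lower of the two numbers, and the gap between them lies well beyond the scatter. The two compounds differ in more than one place, so this gap cannot be assigned to any single change.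

Compound 3 `CC1=C(c2ccc(O)cc2)C(c2ccc(OC[C@H](C)N3CC[C@@H](C)C3)cc2)Oc2ccc(O)cc21` has not yet been measured. It departs from compound 2 in one place only: hydroxy in place of fluoro on an aromatic carbon. This puts hydroxy in place of fluoro on an aromatic carbon, para to a large group, turning 4-fluorophenyl into 4-hydroxyphenyl. Among the measured compounds shown here, the only hydroxy-bearing comparison is compound 1 at 59 nM, and it is weak evidence, since other features differ as well. A modest rise in the number is therefore expected in this assay, reaching only a little beyond the scatter, far short of the gap to compound 1. The expected change is a 3.8-fold higher number from compound 2 to compound 3 (0.57 log units; beyond the scatter). For compound 3 the estimate is 1.5 nM, with an expected range of 0.3 nM to 10 nM.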

Compound 3, half-maximal inhibitory concentration: 0.1 nM
Beside the measured number, compound 3's estimate is 15-fold (1.18 log units) above it; measured number outside the range, below it.
By their numbers in this assay, from the lowest: compound 3; then compound 2; then compound 1.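

In this assay, the change from 4-fluorophenyl to 4-hydroxyphenyl gives a 4.0-fold lower number from compound 2 to compound 3 (0.60 log units; beyond the scatter), a modest step but one beyond the scatter, and it runs towards the stronger inhibitor. Among the compounds shown here, this is the first comparison here that isolates a single change, showing that on this aromatic carbon, para to a large group, hydroxy in place of fluoro does not cost activity on the shared core and instead gains a little, something compound 1 and compound 2 could not show, as they differ in more than one place. Nothing offered here explains why the number falls with this change, so the step stands as an observation without a cause.

The compounds shown leave open whether this gain is particular to hydroxy, since they offer no reading for a methoxy group, an amine or a carboxylic acid at the same position. The gap between compound 1, at 59 nM, and compound 2 also remains unassigned, and no single change can yet be held responsible for it.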